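Cytotoxicity of a styryl-amide oxadiazoline series on lung cells

The source may hold more compounds than are shown below. What is called first, only, known or untested is meant among the compounds shown, and "the series" means these compounds.

The measured compounds and their values:
Compound 1, `O=C(/C=C\c1cccc(O)c1)N1N=C(c2ccncc2)OC1c1c[nH]c2ccccc12`: > 30 ug/mL
Compound 2, `O=C(/C=C\c1ccccc1F)N1N=C(c2ccncc2)OC1c1c[nH]c2ccccc12`: > 30 ug/mL
Compound 3, `O=C(/C=C\c1cccc(Cl)c1)N1N=C(c2ccncc2)OC1c1c[nH]c2ccccc12`: > 30 ug/mL

Compound 1 stands at a limit of the assay rather than at a number. In an ADME assay on A549 cells (Homo sapiens) for cytotoxicity, read by MTT assay, with a stated time of 48 h (on this read-out lower numbers stand for stronger inhibition of growth and higher numbers for weaker inhibition of growth), compound 1 gives > 30 ug/mL, which is a limit. Compound 2 also gives only a limit in this assay, > 30 ug/mL. Compound 3 likewise reaches only a limit, > 30 ug/mL. All three values sit at the same limit (the limit of > 30 ug/mL in this assay, at which 3 of the 3 values shown sit), so none of the steps among them can be read: a step that the two limits leave unreadable from compound 1 to compound 2, a step that the two limits leave unreadable from compound 1 to compound 3 and a step that the two limits leave unreadable from compound 2 to compound 3.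

Compound 4, `O=C(/C=C\c1ccc(Br)cc1)N1N=C(c2ccncc2)OC1c1c[nH]c2ccccc12`, has not yet been measured. It differs from compound 1 as follows: 4-bromophenyl in place of 3-hydroxyphenyl on a double-bonded chain carbon bound to a double-bonded chain carbon. Among the measured compounds shown here, the two steps that touch compound 1 bear on this change, yet both are unreadable, and nothing among the measured compounds shows a readable effect of exchanging the aryl group on the double-bonded chain carbon. The expectation for compound 4 in this assay is therefore a step that the limit leaves unreadable from compound 1 to compound 4, most probably again no number but a limit. Compound 4 is expected to give about 50 ug/mL, within a range from 25 ug/mL to 150 ug/mL.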

Compound 4, concentration for 50% growth inhibition: > 30 ug/mL
Compound 4: only a limit was reported; the forecaster's own chance of this, stated with the estimate: 85%; the middle value lies beyond the limit too.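

In this assay compound 4 gives > 30 ug/mL, which is a limit. Its steps to compound 1, compound 2 and compound 3 cannot be read, so no new step emerges: the limit of > 30 ug/mL in this assay, at which 4 of the 4 values shown sit.

The compounds shown leave open whether exchanging the aryl group on the double-bonded chain carbon changes growth inhibition at all in this assay.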